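A few compounds are considered here, and "the series" means these few. Any claim that something is new, unique, unknown or untested is made for them only; others in the source may bear on it.

Measured compounds:
Compound 1, `CCC(C)(C)Cc1c[nH]c(CCc2ccc(-n3cccn3)cc2)n1`, gives 113 nM in a functional assay on HEK293 cells for agonist activity at Bombesin receptor subtype-3 (Mus musculus), read by luminescence and calcium flux, with a stated time of 10 min; a higher number here means that more compound is needed for the effect, a lower number that less compound is needed.
Compound 2, `CCC(C)(C)Cc1c[nH]c(CCc2ccc(-c3ccc(F)cn3)cc2)n1`, gives 105 nM in this assay.

Among the measured compounds shown here, compound 1 carries the highest of the two numbers, but its only neighbour is compound 2, and the step of a 1.1-fold lower number from compound 1 to compound 2 (0.03 log units; within the scatter) lies within the scatter, so the two compounds cannot be ordered on these data. Both share the same core; they differ only in the aromatic heterocycle at the end of the chain.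

Compound 3, `CCC(C)(C)Cc1c[nH]c(CCc2ccc(-c3csnn3)cc2)n1`, is not yet measured. It is derived from compound 1 by the change (1,2,3-thiadiazol-4-yl in place of 1H-pyrazol-1-yl on an aromatic carbon).

For the measured compounds named here, the only measured step that bears on this change is the one from compound 1 to compound 2, which exchanged the same 1H-pyrazol-1-yl for another aromatic heterocycle at the same place and gave a 1.1-fold lower number from compound 1 to compound 2 (0.03 log units; within the scatter). With the core and chain untouched, and a single comparable exchange showing no movement beyond the scatter, no step beyond the scatter is expected in this assay for compound 3 either.

For compound 3 the expected value in this assay is 110 nM, with a range of 50 nM to 250 nM, corresponding to an estimated step of a 1.0-fold lower number from compound 1 to compound 3 (0.01 log units; within the scatter).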

Compound 3, half-maximal effective concentration: 109 nM
For compound 3 the middle estimate is 1.0-fold (0.00 log units) above the measured one; the measured number falls inside the stated range.
By their numbers in this assay, from the lowest: compounds 2, 3 and 1 (each within the scatter of the next).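

In this assay the exchange of 1H-pyrazol-1-yl for 1,2,3-thiadiazol-4-yl gives a 1.0-fold lower number from compound 1 to compound 3 (0.02 log units; within the scatter) and so adds a third aromatic heterocycle at this place on the six-membered aromatic ring, para to a large group. The exchange brings sulfur into the group and takes the five-membered aromatic ring from 2 hetero atoms to 3, and the replacement of 5-fluoropyridin-2-yl by the same group gives a 1.0-fold higher number from compound 2 to compound 3 (0.02 log units; within the scatter) as a second reading at this place. All three compounds therefore stand within the scatter of one another, so these aromatic groups cannot be told apart in this assay, and no independent data offer an explanation for this.

As far as these compounds go, it remains open whether this tolerance extends beyond aromatic heterocycles, for example to a carboxylic acid, a primary amine or a plain hydrogen at this place. From the compounds shown here alone, it is also open whether the three groups would stay equal if the chain on the shared core were shortened or replaced by a longer chain.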